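This account rests on a few compounds, and the source may have more. Where it says the series, first, only, none or still open, it means among the compounds named here.

Compound 1 `O=C(Nc1cccc(-n2cc(-c3ccncc3)c(-c3cc(O)cc(Cl)c3)n2)c1)Nc1ccc(Cl)c(C(F)(F)F)c1` gives -45% in a functional assay on A549 cells (Homo sapiens) for inhibition, read by sulforhodamine B assay, with a stated time of 48 h, tested at 100 uM; on this read-out higher numbers stand for a weaker effect at the one concentration tested and lower numbers for a stronger effect. Among the measured compounds shown here, compound 2 `COc1cc(Cl)cc(-c2nn(-c3cccc(NC(=O)Nc4ccc(Cl)c(C(F)(F)F)c4)c3)cc2-c2ccncc2)c1` gives -76%, and the single change a number 31 percentage points lower from compound 1 to compound 2 (beyond the scatter) is the one step seen so far. Compound 3 `COc1cc(Cl)cc(-c2nn(-c3cccc(NC(=O)Nc4cc(C(F)(F)F)cc(C(F)(F)F)c4)c3)cc2-c2ccncc2)c1` gives -68%, the second highest of the three numbers; its gap to compound 2 lies within the scatter, while compound 1 sits beyond the scatter on the higher side. Compound 4 `COc1cc(Cl)cc(-c2nn(-c3cccc(NC(=O)Nc4cccc(C(F)(F)F)c4)c3)cc2-c2ccncc2)c1` differs from compound 3 by hydrogen in place of trifluoromethyl on an aromatic carbon. For the measured compounds named here, no measured step concerns this change, and the only step known, the methyl for hydrogen on oxygen, touches a different part of the shared core. Compound 4 is therefore expected to move by a number 8 percentage points higher from compound 3 to compound 4 (within the scatter), a step not beyond the scatter, to an estimated -60% with a range of -82% to -35%.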

Compound 4, a percentage reported as activity, at one concentration (the size of the read-out at that concentration, not a potency): -24%
The estimate for compound 4 lay 36 percentage points below the measured number; the whole stated range lies below it.
By their numbers in this assay, from the lowest: compounds 2 and 3 (each within the scatter of the next); then compound 1; then compound 4.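

In this assay, among the compounds shown here, the ring carrying the urea turns out to be sensitive to losing its second group, something the earlier compounds did not show: trifluoromethyl replaced by hydrogen gives a number 44 percentage points higher from compound 3 to compound 4 (beyond the scatter) and chloro replaced by hydrogen gives a number 52 percentage points higher from compound 2 to compound 4 (beyond the scatter) in this series. A single trifluoromethyl on that ring therefore does not hold the effect, whereas either added group does. Nothing available explains this loss. The compounds shown leave open whether an amine or a carboxylic acid in that place would hold the effect as well.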